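Toward compound 4: a cyclopropyl and a donor enter

The source may report more compounds than this note shows. Statements on the series, on what has been measured and on what is new or still open speak of the compounds shown alone.

Of the compounds shown here, three have so far been measured in an assay on isolated protein for activation of cGMP-dependent protein kinase 1 (Homo sapiens), read by ADP-Glo, with stated times of 30 min and 2 h, in the presence of a further agent that is not named here; on this read-out lower numbers stand for an effect already at smaller amounts and higher numbers for an effect only at larger amounts of compound. Compound 2 `COC(=O)c1ccc(CN2CCC[C@H](O[C@H](CO)c3cc(Cl)cc(Cl)c3)[C@@H]2c2ccccc2)c(C)c1` gives 900 nM, the lowest of the three numbers. Compound 1 `COc1cccc([C@@H](CO)O[C@H]2CCCN(Cc3ccc(C(=O)O)cc3C)[C@H]2c2ccccc2)c1` gives 81000 nM, and compound 3 `Cc1cc(C(=O)O)ccc1CN1CC[C@H](OC(CO)c2cc(Cl)cc(Cl)c2)[C@@H]1c1ccccc1` gives 133000 nM; both lie beyond the scatter from compound 2, and neither differs from compound 2 in a single place, so no single structural step can be read from them.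

Compound 4 `O=C(O)c1ccc(CN2CCC[C@H](O[C@H](CO)c3cc(Cl)cc(Cl)c3)[C@@H]2c2ccccc2)c(C2CC2)c1` has not been measured. It differs from compound 2 by a group of 12 heavy atoms (10 carbon, 2 oxygen; one three-membered non-aromatic ring of carbon only, one six-membered aromatic ring of carbon only) in place of a group of 11 heavy atoms (9 carbon, 2 oxygen; one six-membered aromatic ring of carbon only), on a saturated chain carbon bound to an amine nitrogen in a ring. The entering group carries one hydrogen-bond donor and one hydrogen-bond acceptor where the leaving group carried two acceptors and no donor, as counted above.

Within the data shown here, with no measured single-place step of this kind available, the direction rests on the fact that compound 1 and compound 3 both return higher numbers than compound 2. Compound 4 is therefore expected to show a step upward, a 17-fold higher number from compound 2 to compound 4 (1.22 log units; beyond the scatter), beyond the scatter, with an estimated value of 15000 nM in this assay and a range from 2500 nM to 90000 nM.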

Compound 4, half-maximal effective concentration: 1800 nM
Estimate against measurement, compound 4: 8.3-fold (0.92 log units) above, and the stated range ends above it.
By their numbers in this assay, from the lowest: compounds 2 and 4 (each within the scatter of the next); then compounds 1 and 3 (each within the scatter of the next).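

In this assay, the exchange on a saturated chain carbon bound to an amine nitrogen in a ring gives a 2.0-fold higher number from compound 2 to compound 4 (0.30 log units; within the scatter). Among these compounds, this is the first step that can be read at a single place, and it shows that this place accepts a group with a three-membered ring and a hydrogen-bond donor with no change beyond the usual scatter. The earlier compounds shown here could not show this, as none of them differed from compound 2 in one place alone.

From the compounds shown here alone, the step replaces the group as a whole, so the contributions of the cyclopropyl and the carboxylic acid cannot be separated, and how an ethyl group or a primary amide would read at this place remains open. Nothing in hand explains why the exchange reads as it does.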